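The compounds below may be only part of what the source reports. "The series", "measured", "known", "first", "only" and "open" are said of these compounds alone.

Compound 1 `CNC(=O)[C@@H]1CCCN1S(=O)(=O)c1ccc(Cl)c(COc2cccc3c(OCc4ccccc4)cc(C)nc23)c1Cl` - 1820 mL/min/kg
Compound 2 `CNC(=O)[C@@H]1CCCN1S(=O)(=O)c1ccc(Cl)c(COc2cccc3c(-c4ccccn4)cc(C)nc23)c1Cl` - 733 mL/min/kg
Compound 3 `CNC(=O)[C@@H]1CCCN1S(=O)(=O)c1ccc(Cl)c(COc2cccc3c(-c4ccncc4)cc(C)nc23)c1Cl` - 550 mL/min/kg

In an ADME assay on microsomes (Mus musculus) for metabolic stability (on this read-out lower numbers stand for slow clearance and higher numbers for fast clearance), compound 1 gives 1820 mL/min/kg and stands highest of the three. Compound 4 `CNC(=O)[C@@H]1CCCN1S(=O)(=O)c1ccc(Cl)c(COc2cccc3c(OCc4ccccc4)cc(C(C)C)nc23)c1Cl` keeps the core of compound 1 and differs by isopropyl in place of methyl on an aromatic carbon in one place: isopropyl in place of methyl on an aromatic carbon next to the ring nitrogen. The modest steps of a 2.5-fold lower number from compound 1 to compound 2 (0.39 log units; beyond the scatter) and a 3.3-fold lower number from compound 1 to compound 3 (0.52 log units; beyond the scatter) both replace benzyloxy, which compound 4 keeps, and a 1.3-fold lower number from compound 2 to compound 3 (0.12 log units; within the scatter) lies within the scatter. Going by the values given here, no measured compound alters the methyl, so these steps do not size this change, and no step beyond the scatter is expected in this assay here. The expected step is a 1.0-fold higher number from compound 1 to compound 4 (0.02 log units; within the scatter) in this estimate. For compound 4 the estimated value is 1900 mL/min/kg with an expected range from 1000 mL/min/kg to 3500 mL/min/kg for the measurement.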

Compound 4, clearance: 1220 mL/min/kg
Compound 4: the middle estimate sits 1.6-fold (0.19 log units) above what was measured; measured number inside the range.
By their numbers in this assay, from the lowest: compounds 3, 2, 4 and 1 (each within the scatter of the next, the first and the last beyond it).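

In this assay, going by these compounds alone, this is the first read of the aromatic carbon next to the ring nitrogen: with benzyloxy kept, isopropyl in place of methyl gives a 1.5-fold lower number from compound 1 to compound 4 (0.17 log units; within the scatter). At this position, then, the change stays within the scatter, while the steps beyond it among these compounds remain those that replace benzyloxy. Nothing available explains the result.

Going by these compounds, whether an amine or a carboxylic acid on this carbon would give a step beyond the scatter stays open. So does whether isopropyl gives the same step when pyridin-2-yl or pyridin-4-yl replaces benzyloxy.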